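Series notes: methoxy removal on the fluorophenyl of compound 1

The source may hold more compounds than are shown below. What is called first, only, known or untested is meant among the compounds shown, and "the series" means these compounds.

Measured so far:
- compound 1, `COc1ccc(-n2c(-c3ccc(NC(C)=O)cc3)nc3c2c(=O)n(C)c(=O)n3C)cc1F`; in a functional assay on SK-BR-3 cells (Homo sapiens) for antiproliferative activity, read by MTT assay, with a stated time of 48 h (a higher number here means a weaker inhibitor, a lower number a stronger inhibitor), compound 1 gives 11500 nM
- compound 2, `CNC(=O)Nc1ccc(-c2nc3c(c(=O)n(C)c(=O)n3C)n2-c2ccc(OC)c(F)c2)cc1`; in this assay compound 2 reaches only a limit, > 25000 nM

For the measured compounds named here, compound 1 carries the only numeric value here; the remaining entry sits at the limit of > 25000 nM in this assay, at which 1 of the 2 values shown sits. Going by the values given here, the single measured step, an at least 2.1-fold higher number from compound 1 to compound 2 (0.33 log units; beyond the scatter), replaces methyl with methylamino on a carbonyl carbon and leaves the ring changed below untouched. Compound 3, `CC(=O)Nc1ccc(-c2nc3c(c(=O)n(C)c(=O)n3C)n2-c2cccc(F)c2)cc1`, differs from compound 1 by hydrogen in place of methoxy on an aromatic carbon. Among the compounds with values here, no measured step covers this change, so nothing beyond the scatter is expected, a 1.2-fold higher number from compound 1 to compound 3 (0.09 log units; within the scatter). Compound 3 is estimated at 14000 nM, within 5000 nM to 40000 nM, in this assay.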

Compound 3, half-maximal inhibitory concentration: 15400 nM
Compound 3: the middle estimate sits 1.1-fold (0.04 log units) below what was measured; the range from low to high includes it.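

Going from 3-fluoro-4-methoxyphenyl to 3-fluorophenyl gives a 1.3-fold higher number from compound 1 to compound 3 (0.13 log units; within the scatter) in this assay. For the compounds shown here, this is the first reading at this aromatic position, and in this pair the methoxy is not needed to keep the activity seen with compound 1. No measured data here bear on a cause for this result.

From the compounds shown here alone, whether an amine, a hydroxyl or a longer ethoxy at this position would read differently stays open. Also open, going by these compounds, is whether hydrogen in place of methoxy would read the same alongside the side chain of compound 2, whose value is only a limit.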